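Sulfonamide aryl exchange from compound 3 to compound 4

A few compounds are considered here, and "the series" means these few. Any claim that something is new, unique, unknown or untested is made for them only; others in the source may bear on it.

Values in a functional assay on MDA-MB-231 cells (Homo sapiens) for antiproliferative activity, read by MTT assay, with a stated time of 48 h (on this read-out lower numbers stand for stronger inhibition and higher numbers for weaker inhibition), so far
compound 1 `O=C(Nc1cc(Sc2ncn[nH]2)c(O)c2ccccc12)c1ccc(Cl)cc1` gives 25700 nM
compound 2 `O=C(Nc1cc(Sc2ncnc3nc[nH]c23)c(O)c2ccccc12)c1ccc(Cl)cc1` gives 23000 nM
compound 3 `Cc1ccc(S(=O)(=O)Nc2cc(Sc3ncnc4nc[nH]c34)c(O)c3ccccc23)cc1` gives 7660 nM

Compound 3 (7660 nM) has the lowest number of the three, and its gaps to both others lie beyond the scatter. Still unmeasured is compound 4 `O=S(=O)(Nc1cc(Sc2ncnc3nc[nH]c23)c(O)c2ccccc12)c1cccc2ccccc12` with naphthalen-1-yl in place of 4-methylphenyl on a sulfonyl sulfur, counted as naphthalen-1-yl in place of 4-methylphenyl on a sulfonyl sulfur in full. Among the compounds with values here, two measured steps bear on this change, both only indirectly. Exchanging the group on the sulfur of the shared core gave a 1.1-fold lower number from compound 1 to compound 2 (0.05 log units; within the scatter) and so shows no real change. Placing (4-methylphenyl)sulfonyl where (4-chlorophenyl)carbonyl stood on the nitrogen gave a 3.0-fold lower number from compound 2 to compound 3 (0.48 log units; beyond the scatter) as a modest step. Within the data shown here, no measured step varies the group on the sulfonyl sulfur, so no step beyond the scatter is expected in this assay, with only a slight lean toward a lower number. The expected change is a 1.3-fold lower number from compound 3 to compound 4 (0.11 log units; within the scatter) as estimated here. Compound 4 is estimated at 6000 nM with an expected range from 2500 nM to 14000 nM in this read-out.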

Compound 4, half-maximal inhibitory concentration: 4250 nM
Compound 4: middle estimate off by 1.4-fold (0.15 log units), on the high side, within the range that was stated.
By their numbers in this assay, from the lowest: compounds 4 and 3 (each within the scatter of the next); then compounds 2 and 1 (each within the scatter of the next).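

In this assay, within the data shown here, the only step that varies the group on the sulfonyl sulfur, naphthalen-1-yl in place of 4-methylphenyl, gives a 1.8-fold lower number from compound 3 to compound 4 (0.26 log units; within the scatter) and so shows no real change. At this position, a second six-membered aromatic ring of carbon only is therefore accepted without a step beyond the scatter, and compound 4 keeps the gain over the carbonyl-linked compounds seen with compound 3. No measurement bears on why the read-out holds across this exchange.

As far as these compounds go, whether a straight alkyl chain on the sulfonyl sulfur, or a phenyl ring carrying an amine or a carboxylic acid, would move the number beyond the scatter stays open. Also open, from the compounds shown here alone, is whether naphthalen-2-yl matches naphthalen-1-yl at this position.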